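This account rests on a few compounds, and the source may have more. Where it says the series, first, only, none or still open, it means among the compounds named here.

Working notes on the series. Within the data shown here, in a functional assay on HCT-8 cells (Homo sapiens) for antiproliferative activity, read by MTT assay, with a stated time of 48 h (a lower number here means a stronger inhibitor, a higher number a weaker inhibitor), compound 1 (`COc1ccc(C(=O)c2ccc3c(c2)C=CC(C)(C)O3)c(NC(=O)CBr)c1`) gives 3260 nM, the higher of the two numbers so far. Compound 2 (`COc1ccc(C(=O)c2ccc(OC)c3c2OC(C)(C)C=C3)c(NC(=O)CN)c1`) gives 370 nM, and the gap between them lies beyond the scatter. Compound 3 (`CNCC(=O)Nc1cc(OC)ccc1C(=O)c1ccc2c(c1)C=CC(C)(C)O2`) has methylamino in place of bromo on a saturated chain carbon bound to a carbonyl carbon. Among the measured compounds shown here, no measured step isolates this change, and the only guide is compound 2 at 370 nM, so a lower number beyond the scatter is expected. The expected change is a 4.7-fold lower number from compound 1 to compound 3 (0.67 log units; beyond the scatter). Compound 3 is estimated at 700 nM, with an expected range of 200 nM to 2500 nM.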

Compound 3, half-maximal inhibitory concentration: 1010 nM
For compound 3 the middle estimate is 1.4-fold (0.16 log units) below the measured one; low and high end bracket the measured number.
By their numbers in this assay, from the lowest: compound 2; then compound 3; then compound 1.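

Methylamino in place of bromo on a saturated chain carbon bound to a carbonyl carbon gives a 3.2-fold lower number from compound 1 to compound 3 (0.51 log units; beyond the scatter) in this assay, the first measured step at this place. On the core of compound 1, bromo is therefore not required for activity, and this nitrogen-bearing replacement gives the lower number. Nothing available explains the step. Open, going by these compounds, is whether this step extends to other replacements at this place, such as dimethylamino, hydroxyl or a carboxylic acid, and whether a longer chain would retain it.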